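Swapping an aromatic ring for cyclopropyl on the alkyne

The source may hold more compounds than are shown below. What is called first, only, known or untested is meant among the compounds shown, and "the series" means these compounds.

Three compounds share one core and differ only in the group on the triple-bonded carbon. Compound 1 `CNC(=O)[C@@]12C[C@@H]1[C@@H](n1cnc3c(NC)nc(C#Cc4cccc(C(F)(F)F)c4)nc31)[C@H](O)[C@@H]2O` gives 3.39 nM in an assay on CHO cells for displacement of a labelled ligand from adenosine receptor A3 (Homo sapiens), read by scintillation counting, with a stated time of 60 min; on this read-out higher numbers stand for weaker inhibition and lower numbers for stronger inhibition; compound 2 `CNC(=O)[C@@]12C[C@@H]1[C@@H](n1cnc3c(NC)nc(C#Cc4cc(C)c(C)o4)nc31)[C@H](O)[C@@H]2O` gives 1.45 nM; compound 3 `CNC(=O)[C@@]12C[C@@H]1[C@@H](n1cnc3c(NC)nc(C#Cc4ccsc4)nc31)[C@H](O)[C@@H]2O` gives 0.52 nM, the lowest of the three. The steps were a 2.3-fold lower number from compound 1 to compound 2 (0.37 log units; beyond the scatter), a 6.5-fold lower number from compound 1 to compound 3 (0.81 log units; beyond the scatter) and a 2.8-fold lower number from compound 2 to compound 3 (0.45 log units; beyond the scatter), all modest. Compound 4 `CNC(=O)[C@@]12C[C@@H]1[C@@H](n1cnc3c(NC)nc(C#CC4CC4)nc31)[C@H](O)[C@@H]2O` carries the change (cyclopropyl in place of thiophen-3-yl on a triple-bonded carbon). Within the data shown here, no measured step involves a non-aromatic group here, so these steps guide only loosely; a shift of the same order, upward, is expected, a 4.8-fold higher number from compound 3 to compound 4 (0.68 log units; beyond the scatter). Compound 4 is estimated at 2.5 nM, within 0.7 nM to 10 nM.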

Compound 4, inhibition constant: 1.15 nM
Estimate against measurement, compound 4: 2.2-fold (0.34 log units) above; the measured number falls inside the stated range.
By their numbers in this assay, from the lowest: compound 3; then compounds 4 and 2 (each within the scatter of the next); then compound 1.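

In this assay this place, on a triple-bonded carbon, does not depend on an aromatic ring: cyclopropyl gives a 2.9-fold lower number from compound 1 to compound 4 (0.47 log units; beyond the scatter) and a 1.3-fold lower number from compound 2 to compound 4 (0.10 log units; within the scatter) in the comparisons with the two larger groups. Thiophen-3-yl still holds a modest lead, with a 2.2-fold higher number from compound 3 to compound 4 (0.34 log units; beyond the scatter) as the change. Nothing available here explains these shifts. The compounds shown leave open whether larger non-aromatic rings such as cyclobutyl or cyclohexyl would match cyclopropyl. They also leave open how an open chain such as an aminomethyl or hydroxymethyl group would read at this place.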